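A few compounds are considered here, and "the series" means these few. Any claim that something is new, unique, unknown or untested is made for them only; others in the source may bear on it.

Three compounds have been measured in an assay for inhibition of glucose-6-phosphatase catalytic subunit 1 (Rattus norvegicus), tested at 100 uM; on this read-out higher numbers stand for more inhibition at the one concentration tested (going by the name of the read-out) and lower numbers for less inhibition:
compound 1, `O=C(/C=C/c1ccc(Cl)cc1)C[C@@H]1O[C@H](CO)[C@@H](O)[C@H](O)[C@H]1O`, gives -25.3%
compound 2, `O=C(/C=C/c1ccc2ccccc2c1)C[C@@H]1O[C@H](CO)[C@@H](O)[C@H](O)[C@H]1O`, gives -7.7%
compound 3, `CCOC(=O)C(C(=O)OCC)C(CC(=O)C[C@@H]1O[C@H](CO)[C@@H](O)[C@H](O)[C@H]1O)c1ccccc1`, gives -3.3%

All three numbers are negative, so none of these compounds shows inhibition at the single concentration tested. Compound 3 carries the highest of the three numbers, although compound 2 differs from it only by an amount within the usual scatter of repeated measurements and the two cannot be told apart. Compound 1 lies furthest from compound 3, lower by an amount beyond the scatter. Within the data shown here, no step between any pair of these measured compounds has been worked out, so nothing here connects one structure to another.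

Compound 4, `CCOC(=O)C(C(=O)OCC)C(CC(=O)C[C@@H]1O[C@H](CO)[C@@H](O)[C@H](O)[C@H]1O)c1cccnc1`, has not yet been measured in this assay. It differs from compound 3 in one place: pyridin-3-yl in place of phenyl on a saturated chain carbon bound to two saturated chain carbons. Among the measured compounds shown here, no measured pair shows what this change does to the read-out. The step of a number 0.7 percentage points lower from compound 3 to compound 4 (within the scatter) is expected to be no larger than the scatter and in no clear direction, because compound 3 gives -3.3% and every value seen so far sits at or below zero. Compound 4 is therefore estimated at -4%, with a range from -16% to 8%.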

Compound 4, a percentage reported as inhibition, at one concentration (the size of the read-out at that concentration, not a potency): 37.6%
Beside the measured number, compound 4's estimate is 41.6 percentage points below it; the measured number lies above the stated range.
By their numbers in this assay, from the lowest: compound 1; then compounds 2 and 3 (each within the scatter of the next); then compound 4.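

Putting pyridin-3-yl in place of phenyl on a saturated chain carbon bound to two saturated chain carbons gives, in this assay, a number 40.9 percentage points higher from compound 3 to compound 4 (beyond the scatter) and is the first step among these compounds that can be read at all. It shows that the read-out at this position responds strongly to the ring it carries: the heavy-atom count stays the same and the change adds one ring nitrogen and one hydrogen-bond acceptor, yet compound 4 reaches 37.6% and so shows inhibition at the one concentration tested, where compound 3 shows none. Nothing at hand accounts for the size of this step.

The compounds shown leave open whether pyridin-2-yl, pyridin-4-yl or a phenyl carrying an amine would have the same effect at this carbon, and so whether the placing of the ring nitrogen matters. They also leave open whether the step depends on the ethyl ester groups that compound 3 and compound 4 share, and how potent compound 4 is, as a single concentration gives no potency.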